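The source may report more compounds than this note shows. Statements on the series, on what has been measured and on what is new or still open speak of the compounds shown alone.

Measured compounds:
- compound 1 `CCC(Oc1cccc(CCCn2cc(C(c3ccccc3)c3ccccc3)ccc2=O)c1)C(=O)O`: 502 nM
- compound 2 `CC(C)(Oc1cccc(CCCn2cc(C(c3ccccc3)c3ccccc3)ccc2=O)c1)C(=O)O`: "not determined" (no result reported)

Compound 1 was tested in an assay on HEK293 cells for displacement of a labelled ligand from prostaglandin D2 receptor 2 (Homo sapiens), read by scintillation counting, with a stated time of 2 h (on this read-out higher numbers stand for weaker inhibition and lower numbers for stronger inhibition), and, as compound 1, gives 502 nM. Compound 2 shares the whole core with compound 1 and differs only in the acid-bearing side chain on the ether oxygen, but for compound 2 no number was obtained in this assay, so nothing is known of where it stands.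

Compound 3 `O=C(O)CCCOc1cccc(CCCn2cc(C(c3ccccc3)c3ccccc3)ccc2=O)c1` is the next compound to be measured. Relative to compound 2, the change is 3-carboxypropyl in place of 1-carboxy-1-methylethyl on an oxygen on an aromatic ring. The group that leaves and the group that enters hold the same atoms; the acid is simply moved along an unbranched chain. Among the measured compounds shown here, no measured pair shows this kind of rearrangement, so the direction of the step from compound 2 to compound 3 cannot be read from the data, and compound 1 is the only anchor.

Compound 3 is therefore estimated at 1500 nM, with a range of 300 nM to 8000 nM, allowing for a sizeable step either way.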

Compound 3, half-maximal inhibitory concentration: 11 nM
Compound 3: the middle estimate sits 140-fold (2.13 log units) above what was measured, and the stated range ends above it.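

In this assay, where the acid sits on the chain attached to the aromatic ether oxygen turns out to matter a great deal: replacing 1-carboxypropyl with 3-carboxypropyl gives a 46-fold lower number from compound 1 to compound 3 (1.66 log units; beyond the scatter), a large step well beyond the usual scatter. The core stays the same in this pair, so a change confined to this one side chain is enough to bring compound 3 to 11 nM. Nothing available here explains why moving the acid along the chain has so strong an effect.

On these data alone, the step from compound 2 cannot be read, so the effect of 1-carboxy-1-methylethyl remains unknown. Also open, as far as these compounds go, is whether 2-carboxyethyl, a shorter chain, or 4-carboxybutyl, a longer one, would do better or worse on the same oxygen, and whether an amide or a tetrazole could stand in for the carboxylic acid.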